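The source may hold more compounds than are shown below. What is called first, only, known or untested is meant among the compounds shown, and "the series" means these compounds.

Compound 1 `COc1cc(/C=C2\CN(C)C/C(=C\c3ccccc3F)C2=O)cc(OC)c1`: 6320 nM
Compound 2 `COc1cc(/C=C2\CN(C)C/C(=C\c3ccccc3F)C2=O)cc(OC)c1OC`: 4340 nM
Compound 3 `COc1cc(/C=C2\CN(C)C/C(=C\c3cccc([N+](=O)[O-])c3)C2=O)cc(OC)c1`: not yet measured

All of these numbers come from a functional assay on K562 cells (Homo sapiens) for cytotoxicity, read by MTT assay, with a stated time of 24 h; a higher number here means a weaker inhibitor, a lower number a stronger inhibitor. Within the data shown here, compound 1 has only one measured neighbour so far, and the two cannot be told apart: the data show a 1.5-fold lower number from compound 1 to compound 2 (0.16 log units; within the scatter). Compound 3 keeps the core of compound 1 but carries a new group: 3-nitrophenyl in place of 2-fluorophenyl on a double-bonded chain carbon bound to a double-bonded ring carbon. Among the measured compounds shown here, no measured step covers a change at this place. The only one available, the methoxy in place of hydrogen on an aromatic carbon, is a different change, and it stayed within the scatter. It gives weak guidance at best, so no shift beyond the scatter is expected in this assay, and no direction can be argued firmly. The expected change is a 1.4-fold lower number from compound 1 to compound 3 (0.15 log units; within the scatter). For compound 3 the estimated value is 4500 nM, with an expected range of 1500 nM to 13000 nM.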

Compound 3, half-maximal inhibitory concentration: 4420 nM
Compound 3: middle estimate off by 1.0-fold (0.01 log units), on the high side, and the stated range covers the measured number.
By their numbers in this assay, from the lowest: compounds 2, 3 and 1 (each within the scatter of the next).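

In this assay, among these compounds, the first change at this position, 3-nitrophenyl in place of 2-fluorophenyl on a double-bonded chain carbon bound to a double-bonded ring carbon, gives a 1.4-fold lower number from compound 1 to compound 3 (0.16 log units; within the scatter). The earlier compounds shown here showed only a methoxy change elsewhere on the molecule, whereas this result shows that the group at this place can be exchanged without a readable change in the number. This holds even though the entering group has more heavy atoms than the leaving one and brings hydrogen-bond acceptors that the leaving group lacks.

Still open, on these data alone, is whether an amine, a carboxylic acid or a plain phenyl ring at this place would move the number beyond the scatter. No outside evidence bears on this result.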